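Moving the ethyl group: an expected cytotoxicity for compound 3

A few compounds are considered here, and "the series" means these few. Any claim that something is new, unique, unknown or untested is made for them only; others in the source may bear on it.

Measured so far:
compound 1 `CCc1ccc(-c2nc3c(c(C)nn3-c3ccccc3)c(-c3ccccc3O)c2C#N)cc1` — > 20000 nM
compound 2 `C#Cc1ccccc1-c1c(C#N)c(-c2ccc(CC)cc2)nc2c1c(C)nn2-c1ccccc1` — > 20000 nM

Compound 1 `CCc1ccc(-c2nc3c(c(C)nn3-c3ccccc3)c(-c3ccccc3O)c2C#N)cc1` was tested in an ADME assay on BJ cells (Homo sapiens) for cytotoxicity, with a stated time of 72 h; on this read-out lower numbers stand for an effect already at smaller amounts and higher numbers for an effect only at larger amounts of compound. In this assay compound 1 gives > 20000 nM, which is a limit of the assay and not a number. Compound 2 `C#Cc1ccccc1-c1c(C#N)c(-c2ccc(CC)cc2)nc2c1c(C)nn2-c1ccccc1` carries an ethynyl in place of hydroxy on an aromatic carbon. In this assay compound 2 gives > 20000 nM, again a limit. Going by the values given here, the one measured step, a step that the two limits leave unreadable from compound 1 to compound 2, therefore cannot be sized, because both values sit at the limit of > 20000 nM in this assay, at which 2 of the 2 values shown sit.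

Compound 3 `CCc1cccc(-c2nc3c(c(C)nn3-c3ccccc3)c(-c3ccccc3O)c2C#N)c1` differs from compound 1 by 3-ethylphenyl in place of 4-ethylphenyl on an aromatic carbon. Among the compounds with values here, no measured step bears on this change, and the only step available is unreadable. All that can be said is that compound 1 sits at the limit, so a step in this assay beyond the scatter is not expected in either direction; the most likely outcome for compound 3 is another limit. For compound 3 the expected value in this assay is estimated at 25000 nM, with a range from 10000 nM to 60000 nM. That estimate means an expected step that the limit leaves unreadable from compound 1 to compound 3, within the scatter.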

Compound 3, half-maximal effective concentration: > 20000 nM
Compound 3 was reported as a limit; the forecaster's own chance of this, stated with the estimate: 85%; the middle value does not contradict the limit.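

Replacing 4-ethylphenyl with 3-ethylphenyl gives no readable step from compound 1 to compound 3, because both values, like that of compound 2, are limits and not numbers: the limit of > 20000 nM in this assay, at which 3 of the 3 values shown sit. The compounds shown leave open how far each lies from that limit, and which change would give a measurable cytotoxic effect.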